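A few compounds are considered here, and "the series" means these few. Any claim that something is new, unique, unknown or untested is made for them only; others in the source may bear on it.

Working notes on solubility in the series. Two compounds have numbers in a physicochemical assay for solubility, in phosphate buffer, measured as kinetic solubility, with a stated time of 18 h, at pH 7.4 (on this read-out lower numbers stand for lower solubility and higher numbers for higher solubility), so far. Compound 1 `O=C(Nc1ccc(Cl)cc1)c1cc([N+](=O)[O-])ccc1Cl` gives 3000 nM in this assay. Within the data shown here, compound 2 `CC(Cl)C(=O)Nc1cccc(-c2nc3ccccc3s2)c1` gives 830 nM in this assay, the lower of the two numbers, and the gap to compound 1 lies beyond the scatter; no single-point step between the two measured compounds can be drawn.

The next compound, compound 3 `O=C(Nc1cccc(-c2nc3ccccc3s2)c1)c1ccncc1Cl`, differs from compound 2 in one place: 3-chloropyridin-4-yl in place of 1-chloroethyl on a carbonyl carbon. Among the measured compounds shown here, no measured step of this kind exists, so the direction rests on the change alone. A step no larger than the scatter is expected, with a slight lean downward, and compound 3 is accordingly estimated at 600 nM in this assay, within 150 nM to 2500 nM. The expected step from compound 2 to compound 3 is a 1.4-fold lower number from compound 2 to compound 3 (0.14 log units; within the scatter) in this assay.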

Compound 3, solubility: 320 nM
For compound 3 the middle estimate is 1.9-fold (0.27 log units) above the measured one; low and high end bracket the measured number.
By their numbers in this assay, from the lowest: compound 3; then compound 2; then compound 1.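

Among these compounds, on a carbonyl carbon, the first single-point comparison shows that the group at this place matters in this assay: 3-chloropyridin-4-yl in place of 1-chloroethyl gives a 2.6-fold lower number from compound 2 to compound 3 (0.41 log units; beyond the scatter) and so lowers the number beyond the scatter. The entering group brings a six-membered aromatic ring and a hydrogen-bond acceptor that the leaving group lacks, yet this one pair cannot separate the contributions of those features. No measurement available here bears on the cause of the step.

As far as these compounds go, whether phenyl or unsubstituted pyridin-4-yl on the same carbonyl carbon would follow compound 3 or compound 2 remains open, and so does the role of the chlorine. Also open, from the compounds shown here alone, is the direction of the number with an amine or a carboxylic acid attached at this place.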